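The source may hold more compounds than are shown below. What is called first, only, known or untested is meant among the compounds shown, and "the series" means these compounds.

In a functional assay on HL-60 cells (Homo sapiens) for inhibition, read by MTT assay, with a stated time of 72 h (a lower number here means a stronger inhibitor, a higher number a weaker inhibitor), compound 1 (`CCO[C@@H]1C=CC(=O)[C@@H](CO)O1`) gives 3500 nM, compound 2 (`C#CCO[C@@H]1C=CC(=O)[C@@H](CO)O1`) gives 9300 nM and compound 3 (`C=CCO[C@@H]1C=CC(=O)[C@@H](CO)O1`) gives 4900 nM. Compound 3 thus holds the middle place of the three numbers. Compound 4 (`C#CCCO[C@@H]1C=CC(=O)[C@@H](CO)O1`) has propargyl in place of vinyl on a saturated chain carbon bound to an oxygen on a saturated carbon. Three measured changes at this same place bear on it: a 2.7-fold higher number from compound 1 to compound 2 (0.42 log units; beyond the scatter), a 1.4-fold higher number from compound 1 to compound 3 (0.15 log units; within the scatter) and a 1.9-fold lower number from compound 2 to compound 3 (0.28 log units; within the scatter). Only the first lies beyond the scatter, and it is modest. A triple bond also stands in compound 2, so a slightly higher number is conceivable in this assay, but no step beyond the scatter is expected. The expected step is a 1.2-fold higher number from compound 3 to compound 4 (0.09 log units; within the scatter). For compound 4 the estimated value is 6000 nM, within an expected range from 3000 nM to 12000 nM.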

Compound 4, half-maximal inhibitory concentration: 2500 nM
Estimate against measurement, compound 4: 2.4-fold (0.38 log units) above, outside the stated range (below it).
By their numbers in this assay, from the lowest: compounds 4, 1, 3 and 2 (each within the scatter of the next, the first and the last beyond it).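

A triple bond alone does not set the number at this place: a 3.7-fold lower number from compound 2 to compound 4 (0.57 log units; beyond the scatter) separates two compounds that both carry one. The but-3-yn-1-yl chain nonetheless stays level with the shorter chains, with a 2.0-fold lower number from compound 3 to compound 4 (0.29 log units; within the scatter) and a 1.4-fold lower number from compound 1 to compound 4 (0.15 log units; within the scatter) both inside the scatter. Nothing measured here accounts for the gap between the two triple-bond compounds. Open, on these data alone, is whether a longer chain, an amine or a carboxylic acid at this place would keep the number in this range in this assay and whether the gap would persist.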